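A few compounds are considered here, and "the series" means these few. Any claim that something is new, unique, unknown or untested is made for them only; others in the source may bear on it.

Compound 1 `Cn1c(C[C@]2(c3ccccc3)CCCO2)cc(=O)n(C)c1=O` | 547000 nM
Compound 2 `COc1nc(CC2(c3ccccc3)CO2)cc(=O)n1C` | > 360000 nM | a limit
Compound 3 `COc1nc(CC2(c3ccccc3)CCCO2)cc(=O)n1C` | 130000 nM

All three entries come from a functional assay on MDCK cells (Canis lupus familiaris) for inhibition (a lower number here means that less compound is tolerated, a higher number that more compound is tolerated), on the same cells. Compound 2 gives > 360000 nM as a limit of the assay and not as a number. That leaves two true numbers, and compound 3 holds the lower one at 130000 nM in this assay as its result. Compound 1 stands higher at 547000 nM by a gap beyond the usual scatter.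

The next compound is compound 4 `CCCCOc1nc(CC2(c3ccccc3)CCCO2)cc(=O)n1C` and its change from compound 3 is propyl in place of hydrogen on a saturated chain carbon bound to an oxygen on an aromatic ring in full. In plain terms, propyl replaces hydrogen on a saturated chain carbon bound to an oxygen on an aromatic ring, which turns methoxy into butoxy. Within the data shown here, no two measured compounds differ in one place alone, so no measured step speaks directly to this change. A modest step toward a lower number is expected, and it may not clear the scatter. The expected move is a 2.0-fold lower number from compound 3 to compound 4 (0.30 log units; within the scatter) in size. Compound 4 is estimated at 65000 nM with an expected range from 20000 nM to 200000 nM as a deliberately wide span.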

Compound 4, half-maximal cytotoxic concentration: 90000 nM
Beside the measured number, compound 4's estimate is 1.4-fold (0.14 log units) below it, and the stated range covers the measured number.
By their numbers in this assay, from the lowest: compounds 4 and 3 (each within the scatter of the next); then compound 1.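

Among these compounds, compounds 3 and 4 are the first pair here that differ in one place only, so this is the first direct reading of a change at this position, free of any other difference in the molecule. In this assay, the step is a 1.4-fold lower number from compound 3 to compound 4 (0.16 log units; within the scatter), so turning methoxy into butoxy, with propyl in place of hydrogen on the saturated chain carbon bound to an oxygen on an aromatic ring, gives no difference that can be told apart from the ordinary spread of repeat measurements. Nothing shown offers a reason for the size of this step.

From the compounds shown here alone, a single step cannot show a trend with chain length, so it remains open whether a longer chain such as octyloxy would shift the half-maximal cytotoxic concentration beyond the scatter. Going by these compounds, it also remains open whether a group of a different kind in place of butoxy, such as an amine or a carboxylic acid, would leave the number as little changed as propyl does in this assay.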